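The compounds below may be only part of what the source reports. "The series", "measured", "known", "first", "only" and "open" are said of these compounds alone.

Of the compounds shown here, three have so far been measured in a physicochemical assay for lipophilicity, at pH 7.4; a lower number here means a more polar compound, a higher number a more lipophilic compound. Compound 1 `CNC(=O)c1ccc(=O)n(Cc2cc(Br)ccc2F)c1` gives 2.6 in this assay, compound 2 `CNC(=O)c1cc(C(=O)NC2CC2)cn(Cc2cccc3cn[nH]c23)c1=O` gives 2.2, and compound 3 `CNC(=O)c1cc(C(=O)NC2CCC2)cn(Cc2cccnc2)c1=O` gives 1.8. Compound 2 therefore stands second highest of the three: compound 1 lies higher by more than the usual scatter, and compound 3 lies lower by more than the usual scatter. Within the data shown here, no two of the measured compounds differ in only one place, so no measured step is available to lean on.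

Compound 4 `CNC(=O)c1cc(C(=O)NC2CC2)cn(Cc2cccc3cc[nH]c23)c1=O` has not yet been measured in this assay. It differs from compound 2 in one place: 1H-indol-7-yl in place of 1H-indazol-7-yl on a saturated chain carbon bound to an aromatic nitrogen. In the counted difference, one hydrogen-bond acceptor and one nitrogen are dropped while the donor and the number of heavy atoms are kept. Among the measured compounds shown here, nothing among the measured compounds shows what a change of this kind does here, so the expectation rests on the change itself: a modest rise in this assay from compound 2 to compound 4, somewhat beyond the usual scatter rather than within it. Compound 4 is accordingly expected to give 2.6 in this assay, within a range from 2.2 to 3. The step that this estimate means is expected to be a number 0.40 log units higher from compound 2 to compound 4 (beyond the scatter).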

Compound 4, distribution coefficient: 3.7
Estimate against measurement, compound 4: 1.10 log units below, outside the stated range (above it).
By their numbers in this assay, from the lowest: compound 3; then compound 2; then compound 1; then compound 4.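

In this assay, 1H-indol-7-yl in place of 1H-indazol-7-yl on a saturated chain carbon bound to an aromatic nitrogen gives a number 1.50 log units higher from compound 2 to compound 4 (beyond the scatter), the only measured step among these compounds and a large one. Among these compounds, the read-out at this position therefore responds strongly to a single change that keeps 9 heavy atoms and 1 hydrogen-bond donor, replaces one nitrogen with carbon and takes the hydrogen-bond acceptors from 1 to 0, something the earlier compounds, which differ in more than one place, could not show. Nothing available here establishes the cause of the step.

The compounds shown leave open whether a step of this size would recur with the rest of compound 2 changed, since this one pair is the only comparison at this position. They also leave open where the number would fall with a carboxylic acid or a primary amine on the 1H-indol-7-yl group of compound 4, and whether either would bring the value in this assay back towards that of compound 2.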